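Trimming the Amide Aryl Group: Compound 3 to Compound 4

A few compounds are considered here, and "the series" means these few. Any claim that something is new, unique, unknown or untested is made for them only; others in the source may bear on it.

Within the data shown here, compound 3 `COc1cc(-c2nn(-c3cccc(NC(=O)c4ccc(Cl)c(C(F)(F)F)c4)c3)cc2-c2ccncc2)ccc1Cl` gives 2400 nM in a functional assay on A549 cells (Homo sapiens) for inhibition, read by sulforhodamine B assay, with a stated time of 48 h (a higher number here means a weaker inhibitor of growth, a lower number a stronger inhibitor of growth), the highest number of the three measured so far. Compound 1 `COc1cc(-c2nn(-c3cccc(NC(=O)Nc4ccc(Cl)c(Cl)c4)c3)cc2-c2ccncc2)ccc1Cl` gives 745 nM, and compound 2 `O=C(Nc1cccc(-n2cc(-c3ccncc3)c(-c3ccc(Cl)c(O)c3)n2)c1)Nc1ccc(Cl)c(Cl)c1` gives 1010 nM. The change a 1.4-fold higher number from compound 1 to compound 2 (0.13 log units; within the scatter) sits at a different place from the step considered here, while the change a 3.2-fold higher number from compound 1 to compound 3 (0.51 log units; beyond the scatter) altered the same carbonyl position and was a modest weakening. Compound 4 `COc1cc(-c2nn(-c3cccc(NC(=O)c4ccccc4)c3)cc2-c2ccncc2)ccc1Cl` differs from compound 3 by phenyl in place of 4-chloro-3-(trifluoromethyl)phenyl on a carbonyl carbon. Among the measured compounds shown here, no measured step strips groups from this ring, so the evidence is thin; a modest rise in the number, or no step beyond the scatter, seems most likely. Compound 4 is therefore expected to give about 4500 nM, within 1500 nM to 13000 nM. The step expected here, a 1.9-fold higher number from compound 3 to compound 4 (0.27 log units; within the scatter), is a modest one.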

Compound 4, concentration for 50% growth inhibition: 585 nM
The estimate for compound 4 lay 7.7-fold (0.89 log units) above the measured number; the measured number lies below the stated range.
By their numbers in this assay, from the lowest: compounds 4, 1 and 2 (each within the scatter of the next); then compound 3.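

On this carbonyl carbon, taking away the chlorine and the trifluoromethyl helps rather than hurts in this assay (a 4.1-fold lower number from compound 3 to compound 4 (0.61 log units; beyond the scatter)), so the 4-chloro-3-(trifluoromethyl)phenyl group is not needed for growth inhibition here. Plain phenyl and the (3,4-dichlorophenyl)amino group cannot be told apart at this place (a 1.3-fold lower number from compound 1 to compound 4 (0.11 log units; within the scatter)), so the smaller group serves as well as the larger one. Nothing measured here accounts for either step. Going by these compounds, whether the chlorine or the trifluoromethyl drives the loss seen with compound 3 stays open. So does how an amine or a carboxylic acid on the phenyl ring of compound 4 would change the number.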